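Aryl amine variation in the thioether series, compounds 1 to 3

The compounds below may be only part of what the source reports. "The series", "measured", "known", "first", "only" and "open" are said of these compounds alone.

Compound 1 `FC(F)(F)c1ccc(CSc2nc(Nc3ccccc3Cl)c3ccccc3n2)cc1` reaches only the limit of a functional assay on HGC-27 cells (Homo sapiens) for cytotoxicity, read by MTT assay, with a stated time of 72 h (a lower number here means a stronger inhibitor, a higher number a weaker inhibitor), where compound 1 reports > 50000 nM. Compound 2 `Cc1ccc(Nc2nc(SCc3ccc(C(F)(F)F)cc3)nc3ccccc23)cc1` carries a 4-methylphenyl in place of the 2-chlorophenyl on the nitrogen on the aromatic ring, and in this assay compound 2 gives 34600 nM. The change reads an at least 1.4-fold lower number from compound 1 to compound 2 (0.15 log units; that floor lies within the scatter). Among the compounds with values here, compound 2 therefore holds the only number in this assay; the other value shown is a limit (the limit of > 50000 nM in this assay, at which 1 of the 2 values shown sits), so no ranking between the two can be drawn.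

Compound 3 `COc1cc(Nc2nc(SCc3ccc(C(F)(F)F)cc3)nc3ccccc23)cc(OC)c1` differs from compound 2 by 3,5-dimethoxyphenyl in place of 4-methylphenyl on a nitrogen on an aromatic ring. Within the data shown here, the only measured step at this position, the one from compound 1 to compound 2, is itself no more than a floor within the scatter, and it concerns a different pair of groups, so it gives no direction for the present change. The expectation for compound 3 is accordingly a step of a 1.2-fold lower number from compound 2 to compound 3 (0.06 log units; within the scatter), nothing beyond the scatter, with a fair chance that the assay again returns only a limit. Compound 3 is estimated at 30000 nM in this assay, between 10000 nM and 90000 nM.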

Compound 3, half-maximal inhibitory concentration: > 50000 nM
Compound 3 gave a limit, no number; the forecaster's own chance of this, stated with the estimate: 40%; middle value at least 1.6-fold (0.22 log units) from the limit.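

In this assay, the exchange of (4-methylphenyl)amino for (3,5-dimethoxyphenyl)amino gives an at least 1.4-fold higher number from compound 2 to compound 3 (0.15 log units; that floor lies within the scatter), so this change shows no step beyond the scatter, although the floor leaves the true size open. Compound 3 is a limit and not a number, > 50000 nM. The step between compound 1 and compound 3 cannot be read, and the 3,5-dimethoxyphenyl now joins the 2-chlorophenyl at the limit, leaving the 4-methylphenyl of compound 2 as the only group at this position with a number: the limit of > 50000 nM in this assay, at which 2 of the 3 values shown sit.

The compounds shown leave open whether any group on this nitrogen can give a number clearly apart from that of compound 2, for example a phenyl ring carrying an amine or a carboxylic acid. As far as these compounds go, the thioether side is the same in all three compounds, so what a change there, such as a longer chain, would do in this assay also remains open.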